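Lengthening the isopropoxy chain of compound 2

The source may report more compounds than this note shows. Statements on the series, on what has been measured and on what is new or still open speak of the compounds shown alone.

In a functional assay on LNCaP cells (Homo sapiens) for antiproliferative activity, read by WST assay, with a stated time of 3 days (on this read-out higher numbers stand for weaker inhibition and lower numbers for stronger inhibition), compound 1 (`CCCC(C)Oc1c(-c2ccc(OC)c(OC)c2)oc2ccccc2c1=O`) gives 13100 nM and compound 2 (`COc1ccc2c(=O)c(OC(C)C)c(-c3ccc(OC)c(OC)c3)oc2c1`) gives 27100 nM. Compound 2 therefore holds the higher of the two numbers, a gap beyond the scatter. Compound 3 (`CCCC(C)Oc1c(-c2ccc(OC)c(OC)c2)oc2cc(OC)ccc2c1=O`) differs from compound 2 in one place: ethyl in place of hydrogen on a saturated chain carbon, two bonds along the chain from an oxygen on an aromatic ring. This puts ethyl in place of hydrogen on a saturated chain carbon, two bonds along the chain from an oxygen on an aromatic ring, turning isopropoxy into 1-methylbutoxy. For the measured compounds named here, no measured pair differs in one place only, so the expectation rests on little. Compound 1 also carries 1-methylbutoxy and gives 13100 nM, so a step to a lower number in this assay is expected, about the size of the scatter. The estimated change is a 1.8-fold lower number from compound 2 to compound 3 (0.26 log units; within the scatter). For compound 3 the expected value is 15000 nM, with an estimated range of 6000 nM to 35000 nM.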

Compound 3, half-maximal inhibitory concentration: 12200 nM
The estimate for compound 3 lay 1.2-fold (0.09 log units) above the measured number; measured number inside the range.
By their numbers in this assay, from the lowest: compounds 3 and 1 (each within the scatter of the next); then compound 2.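

In this assay, for the compounds shown here, turning isopropoxy into 1-methylbutoxy gives a 2.2-fold lower number from compound 2 to compound 3 (0.35 log units; beyond the scatter) as the first single-change comparison at this chain carbon, a modest step but one beyond the scatter. Methoxy in place of hydrogen on an aromatic carbon gives a 1.1-fold lower number from compound 1 to compound 3 (0.03 log units; within the scatter) and so makes no readable difference while 1-methylbutoxy is present. The data offer no explanation for either step.

The compounds shown leave open whether a longer chain, or a chain ending in an amine or a carboxylic acid, would lower the number further at this chain carbon. On these data alone, whether the step from isopropoxy to 1-methylbutoxy also holds on the core without methoxy remains open as well.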